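Nitro for bromo on two sulfonamide cores

This account rests on a few compounds, and the source may have more. Where it says the series, first, only, none or still open, it means among the compounds named here.

Measured so far in a physicochemical assay for acid dissociation:
compound 1 `O=S(=O)(Nc1ccccc1)c1cccc(Br)c1` gives 8.25;
compound 2 `O=[N+]([O-])c1cccc(S(=O)(=O)Nc2ccccc2)c1` gives 7.5;
compound 3 `O=[N+]([O-])c1cccc(NS(=O)(=O)c2ccc(Br)cc2)c1` gives 7.42.

The difference between the core of compound 1 and the core of compound 3 is not broken down here. Compound 3 and compound 2 lie within the scatter of each other, while compound 1 stands apart from both.

Compound 4 `O=[N+]([O-])c1ccc(S(=O)(=O)Nc2cccc([N+](=O)[O-])c2)cc1` is not yet measured. It arises from compound 3 by nitro in place of bromo on an aromatic carbon. The same kind of change was made from compound 1 to compound 2, (nitro in place of bromo on an aromatic carbon), where the place differs: there the new group sits meta to a large group, here para to a large group. That earlier change gave a number 0.75 log units lower from compound 1 to compound 2 (beyond the scatter).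

Resting on the step seen from compound 1 to compound 2, a step of at least similar size is expected for compound 4, a number 0.92 log units lower from compound 3 to compound 4 (beyond the scatter). The estimate for compound 4 in this assay is 6.5, between 6.1 and 6.9.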

Compound 4, acid dissociation constant: 5.51
Compound 4: middle estimate off by 0.99 log units, on the high side; the measured number lies below the stated range.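

In this assay the change from bromo to nitro gives a number 1.91 log units lower from compound 3 to compound 4 (beyond the scatter) on this core and a number 0.75 log units lower from compound 1 to compound 2 (beyond the scatter) on the other, so the direction carried across while the size did not. Among the compounds shown here, these are only two pairs, and here the nitro also sits para to a large group, which it does not do in the earlier pair, so the effect of the core cannot be separated from the effect of the place. Nothing available speaks to why the second step is the larger one.

The compounds shown leave open whether a nitrile or a carboxylic acid in the same place would give a similar step. They also leave open what nitro para to a large group would do on the core of compound 1.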